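Swapping the aryl substituent on a kinase-binding scaffold

A few compounds are considered here, and "the series" means these few. Any claim that something is new, unique, unknown or untested is made for them only; others in the source may bear on it.

Compound 3 `CCCS(=O)(=O)Nc1ccc(F)c(C(=O)c2n[nH]c3ncc(-c4ccc(C)c(C)c4)cc23)c1F` sits in the middle of three measured compounds. In an assay for binding affinity to dual specificity mitogen-activated protein kinase kinase 4 (Homo sapiens), read by KINOMEscan, tested at 100 nM (on this read-out lower numbers stand for a stronger effect and higher numbers for a weaker effect at the one concentration tested), compound 3 gives 20%. Its nearest neighbour is compound 1 `CCCS(=O)(=O)Nc1ccc(F)c(C(=O)c2n[nH]c3ncc(-c4ccc(C)cc4)cc23)c1F`, which in this assay gives 5.4%; the step of a number 14.6 percentage points higher from compound 1 to compound 3 (beyond the scatter) came with a methyl in place of hydrogen on an aromatic carbon. The furthest is compound 2 `CCCS(=O)(=O)Nc1ccc(F)c(C(=O)c2n[nH]c3ncc(-c4cc(Cl)cc(Cl)c4)cc23)c1F`, which in this assay gives 73%, and the step of a number 53 percentage points lower from compound 2 to compound 3 (beyond the scatter) came with 3,4-dimethylphenyl in place of 3,5-dichlorophenyl on an aromatic carbon. The third measured step, a number 67.6 percentage points higher from compound 1 to compound 2 (beyond the scatter), also changed only the pendant ring.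

Compound 4 `CCCS(=O)(=O)Nc1ccc(F)c(C(=O)c2n[nH]c3ncc(-c4ccc(S(C)(=O)=O)cc4)cc23)c1F` differs from compound 3 by 4-(methylsulfonyl)phenyl in place of 3,4-dimethylphenyl on an aromatic carbon. All three measured steps bear on it, since each altered the same pendant ring, and two of them were large. For the measured compounds named here, none of the measured compounds carries oxygen or sulfur on that ring, so the data give no direct precedent for this entering group, and the outcome could fall anywhere across the measured span. A step of roughly a number 15 percentage points higher from compound 3 to compound 4 (beyond the scatter) is expected, though with wide uncertainty. For compound 4 in this assay the estimate is 35%, within a range of 5% to 85%.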

Compound 4, a percentage reported as activity, at one concentration (the size of the read-out at that concentration, not a potency): 1.5%
The estimate for compound 4 lay 33.5 percentage points above the measured number, outside the stated range (below it).
By their numbers in this assay, from the lowest: compounds 4 and 1 (each within the scatter of the next); then compound 3; then compound 2.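

In this assay, a sulfur- and oxygen-bearing group on the pendant ring proves compatible with a low number, with a number 18.5 percentage points lower from compound 3 to compound 4 (beyond the scatter) and, against the dichlorinated ring, a number 71.5 percentage points lower from compound 2 to compound 4 (beyond the scatter). The closest comparison is a number 3.9 percentage points lower from compound 1 to compound 4 (within the scatter), so exchanging methyl for methylsulfonyl at the same place on the ring leaves no distinguishable difference, even though the two groups differ greatly in their atoms. Across these four compounds, the rings with a single group, 4-methylphenyl and 4-(methylsulfonyl)phenyl, give lower numbers than 3,4-dimethylphenyl and 3,5-dichlorophenyl, but nothing available explains why this ring tolerates such different groups.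

As far as these compounds go, it remains open whether this tolerance extends to a 4-aminophenyl or 4-carboxyphenyl ring, or to a longer chain on the sulfonyl group, such as ethylsulfonyl. It is also unclear whether the single-group pattern depends on where the group sits, since a 3-(methylsulfonyl)phenyl ring would separate the effect of the group from that of its place on the ring.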